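Trimming isobutoxy to methoxy under a cytotoxicity ceiling

The compounds below may be only part of what the source reports. "The series", "measured", "known", "first", "only" and "open" are said of these compounds alone.

Three compounds share one core and differ only in the group on one aromatic carbon. Compound 1 `CC(=O)Nc1cccc(-c2ccc(C(=O)N(Cc3cccc(OCCCCCC(=O)O)c3)C(C)C)cc2)c1` carries acetamido there. In an ADME assay on BJ cells (Homo sapiens) for cytotoxicity, read by CellTiter-Glo and resazurin assay, with a stated time of 72 h (a lower number here means that less compound is needed, a higher number that more compound is needed for the effect), compound 1 gives only a limit, > 26000 nM. Compound 2 `CC(C)N(Cc1cccc(OCCCCCC(=O)O)c1)C(=O)c1ccc(-c2cccc(-c3ccccc3)c2)cc1` carries phenyl in place of acetamido. In this assay compound 2 also gives only a limit, > 26000 nM. Compound 3 `CC(C)COc1cccc(-c2ccc(C(=O)N(Cc3cccc(OCCCCCC(=O)O)c3)C(C)C)cc2)c1` carries isobutoxy. In this assay compound 3 again gives only a limit, > 26000 nM. Because of the limit of > 26000 nM in this assay, at which 3 of the 3 values shown sit, the steps a step that the two limits leave unreadable from compound 1 to compound 2, a step that the two limits leave unreadable from compound 1 to compound 3 and a step that the two limits leave unreadable from compound 2 to compound 3 cannot be sized, and compound 3 stands level with the other two. Compound 4 `COc1cccc(-c2ccc(C(=O)N(Cc3cccc(OCCCCCC(=O)O)c3)C(C)C)cc2)c1` is the next member: hydrogen in place of isopropyl on a saturated chain carbon bound to an oxygen on an aromatic ring. Within the data shown here, none of the measured steps has a readable size, so nothing among them points to a direction for this change. The expectation is that compound 4 again sits at or beyond the limit, a step that the limit leaves unreadable from compound 3 to compound 4 of no readable size. Compound 4 is estimated at 40000 nM, within a range from 15000 nM to 150000 nM.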

Compound 4, half-maximal effective concentration: > 20900 nM
Compound 4: a limit, no number; the forecaster's own chance of this, stated with the estimate: 85%; the middle value lies beyond the limit too.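

In this assay compound 4 gives > 20900 nM, a limit and not a number. The steps from compound 1, compound 2 and compound 3 to compound 4 therefore cannot be read. Still open, from the compounds shown here alone, is what concentration of any of these four compounds produces the effect, and whether the differing group changes it.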